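Thiophen-2-yl for Furan-2-yl at the Benzylic-Type Carbon

The source may report more compounds than this note shows. Statements on the series, on what has been measured and on what is new or still open speak of the compounds shown alone.

Measured in a functional assay on the whole organism (plasma, strain Sprague-Dawley) with Rattus norvegicus as the target, with a stated time of 2 h, at a dose of 25 mg/kg by the oral route; on this read-out lower numbers stand for a weaker effect and higher numbers for a stronger effect at the one dose given:
compound 1 `c1ccc(C(/N=C2\CCCCCCN2)C2CC2)cc1` gives 26%
compound 2 `c1ccc(C(/N=C2\CCCCCCN2)c2ccco2)cc1` gives 29%

Of the compounds shown here, two have been measured, and they sit close together. Among the compounds with values here, the one step between them, a number 3 percentage points higher from compound 1 to compound 2 (within the scatter), comes from exchanging the group on a saturated chain carbon bound to an aromatic carbon and a double-bonded nitrogen, furan-2-yl in place of cyclopropyl, and it did not move the read-out beyond the scatter. Compound 2 therefore stands beside compound 1 rather than apart from it.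

Compound 3 `c1ccc(C(/N=C2\CCCCCCN2)c2cccs2)cc1` has not yet been measured. It differs from compound 2 by thiophen-2-yl in place of furan-2-yl on a saturated chain carbon bound to an aromatic carbon and a double-bonded nitrogen. Within the data shown here, the only step that bears on it is a number 3 percentage points higher from compound 1 to compound 2 (within the scatter), which changed the same place and stayed within the scatter. Nothing measured here suggests that a second exchange at that place should do more. The expected step of a number 1 percentage points higher from compound 2 to compound 3 (within the scatter) is therefore none beyond the scatter. On that basis compound 3 is estimated to give 30% in this assay, with a likely range from 15% to 45%.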

Compound 3, a percentage reported as inhibition, in the whole organism at one dose (the size of the read-out at that dose, not a potency): 37%
Compound 3: the middle estimate sits 7 percentage points below what was measured; the measured number falls inside the stated range.
By their numbers in this assay, from the lowest: compounds 1, 2 and 3 (each within the scatter of the next, the first and the last beyond it).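

At the saturated chain carbon bound to an aromatic carbon and a double-bonded nitrogen, placing thiophen-2-yl in place of furan-2-yl gave in this assay a number 8 percentage points higher from compound 2 to compound 3 (within the scatter) and so cannot be told apart from no change, even though the two groups differ only in one ring atom, sulfur for oxygen. Within the data shown here, measured against cyclopropyl, however, thiophen-2-yl gave a number 11 percentage points higher from compound 1 to compound 3 (beyond the scatter) and thereby provides the first evidence that the read-out responds to the group held at this place, though the effect is modest and rests on this one pair. No measurement available here explains why thiophen-2-yl stands clear of cyclopropyl while furan-2-yl does not.

The compounds shown leave open whether this modest gain extends to other groups at the same place, such as a phenyl ring, a primary amine or a longer alkyl chain, or whether it is confined to thiophen-2-yl. They also leave open whether the gap between compound 1 and compound 3 would persist at other doses or time points, since a read-out at a single dose is not a potency.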